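Chain homologation of the basic side chain on the shared core

This account rests on a few compounds, and the source may have more. Where it says the series, first, only, none or still open, it means among the compounds named here.

Measured so far in a functional assay on K562 cells (Homo sapiens) for antiproliferative activity, read by MTT assay, with a stated time of 48 h; a higher number here means a weaker inhibitor, a lower number a stronger inhibitor:
- compound 1, `CN(C)CCn1c(N)c(-c2nc3ccccc3[nH]2)c2nc(C#N)c(C#N)nc21`: 6340 nM
- compound 2, `CCN(CC)CCn1c(N)c(-c2nc3ccccc3[nH]2)c2nc(C#N)c(C#N)nc21`: 2490 nM
- compound 3, `N#Cc1nc2c(-c3nc4ccccc4[nH]3)c(N)n(CCO)c2nc1C#N`: only a limit, > 50000 nM

Compound 1 stands highest of the two numbers; compound 2 sits below it, a 2.5-fold lower number from compound 1 to compound 2 (0.41 log units; beyond the scatter). Compound 3 reaches only the limit (the limit of > 50000 nM in this assay, at which 1 of the 3 values shown sits). From this come the steps of an at least 7.8-fold higher number from compound 1 to compound 3 (0.89 log units; beyond the scatter) and an at least 20-fold higher number from compound 2 to compound 3 (1.30 log units; beyond the scatter), so removing the basic amine altogether costs much, while enlarging its alkyl groups brought a modest gain.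

Compound 4, `CN(C)CCCn1c(N)c(-c2nc3ccccc3[nH]2)c2nc(C#N)c(C#N)nc21`, differs from compound 1 by (dimethylamino)methyl in place of dimethylamino on a saturated chain carbon, two bonds along the chain from an aromatic nitrogen. For the measured compounds named here, no measured step changes the chain length itself; the closest comparison is compound 1 to compound 2, which kept the chain and varied the amine and gave only a modest step. The tertiary amine is kept in compound 4, so the large losses seen on going to hydroxy do not apply. The expectation is therefore a step within the usual scatter, leaning if anything slightly toward a lower number, a 1.3-fold lower number from compound 1 to compound 4 (0.10 log units; within the scatter). Compound 4 is estimated at 5000 nM, with a range from 1800 nM to 14000 nM.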

Compound 4, half-maximal inhibitory concentration: 1730 nM
Compound 4: middle estimate off by 2.9-fold (0.46 log units), on the high side; the whole stated range lies above it.
By their numbers in this assay, from the lowest: compounds 4 and 2 (each within the scatter of the next); then compound 1. At a limit, above all of these: compound 3.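

In this assay, the extension from 2-(dimethylamino)ethyl to 3-(dimethylamino)propyl gives a change beyond the scatter (a 3.7-fold lower number from compound 1 to compound 4 (0.56 log units; beyond the scatter)), so at this position the length of the chain matters as well as the alkyl groups on the amine. The extension and the diethylamino change, each made on compound 1, end within the scatter of each other (a 1.4-fold lower number from compound 2 to compound 4 (0.16 log units; within the scatter)), so these compounds offer two separate changes that reach the same level. The longer chain with its dimethylamino group also stands far from the hydroxy chain (an at least 28-fold lower number from compound 3 to compound 4 (1.46 log units; beyond the scatter)), and that step is only a bound, as compound 3 stands at a limit: the limit of > 50000 nM in this assay, at which 1 of the 4 values shown sits.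

With only two chain lengths in hand, the compounds shown do not tell whether a longer chain such as 4-(dimethylamino)butyl would go further or lose ground. They also leave open whether diethylamino on the propyl chain would add to the extension, and how a ring amine such as morpholine or piperidine would behave at the end of either chain.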